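Cyano for chloro on the aryl ring: stability outlook

This account rests on a few compounds, and the source may have more. Where it says the series, first, only, none or still open, it means among the compounds named here.

Notes on the series. Compound 1 `CC(=O)N1CCN(c2cc(C)cc(-c3cc(Cl)c4c(N)ncnn34)c2)C(=O)C1(C)C` gives 92% in an ADME assay on microsomes from liver (Homo sapiens) for metabolic stability, read by LC-MS, using NADPH, with stated times of 6 min and 10 min, tested at 0.5 uM; on this read-out higher numbers stand for a more stable compound and lower numbers for a less stable compound. Compound 2 `CC(=O)N1CCN(c2cc(-c3cc(Cl)c4c(N)ncnn34)ccc2C(F)(F)F)C(=O)C1(C)C` gives 95% in this assay, and compound 3 `CC(=O)N1CCN(c2cc(-c3cc(Cl)c4c(N)ncnn34)ccc2Cl)C(=O)C1(C)C` gives 85%. Compound 3 thus holds the lowest of the three numbers, but its gap to compound 1 and its gap to compound 2 both lie within the scatter, so no order among the three compounds can be claimed.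

Going by the values given here, the single measured step, a number 10 percentage points lower from compound 2 to compound 3 (within the scatter), exchanges the group on the same aromatic carbon that is altered next, and it stayed within the scatter.

Compound 4 `CC(=O)N1CCN(c2cc(-c3cc(Cl)c4c(N)ncnn34)ccc2C#N)C(=O)C1(C)C` differs from compound 3 by cyano in place of chloro on an aromatic carbon. Among the compounds with values here, no measured step exchanges chloro for cyano, so the expectation rests on a number 10 percentage points lower from compound 2 to compound 3 (within the scatter), which moved the read-out only within the scatter. The step of a number 2 percentage points higher from compound 3 to compound 4 (within the scatter) is therefore expected to remain within the scatter, with no direction beyond it. Compound 4 is accordingly estimated at 87% in this assay, within a range from 74% to 97%.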

Compound 4, percent of the compound remaining: 90%
Beside the measured number, compound 4's estimate is 3 percentage points below it, and the stated range covers the measured number.
By their numbers in this assay, from the lowest: compounds 3, 4, 1 and 2 (each within the scatter of the next).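

At this aromatic carbon, ortho to a large group and para to a large group, cyano now joins chloro and trifluoromethyl as a third group read in this assay, and it adds a triple bond and a hydrogen-bond acceptor to what this position has been seen to carry. With a number 5 percentage points higher from compound 3 to compound 4 (within the scatter) and a number 5 percentage points lower from compound 2 to compound 4 (within the scatter), the exchange of groups here has so far stayed inside the scatter, and no order among the three groups can be claimed. No measurement at hand speaks to why the read-out holds across these groups.

On these data alone, whether an amine, a carboxylic acid or a longer chain on this carbon would also stay within the scatter in this assay remains open. Also open, as far as these compounds go, is whether cyano in place of chloro would read the same on a different core.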